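Working notes on compound 2 and compound 3

A few compounds are considered here, and "the series" means these few. Any claim that something is new, unique, unknown or untested is made for them only; others in the source may bear on it.

The series shares one core, seen in compound 1 `C[Se]/C(=N\C(=O)c1cc2ccccc2s1)NC(=O)c1cc2ccccc2s1` and compound 2 `CS/C(=N\C(=O)c1cc2ccccc2s1)NC(=O)c1cc2ccccc2s1`. In a functional assay on HT-29 cells (Homo sapiens) for cytotoxicity, read by MTT assay, with a stated time of 72 h (on this read-out lower numbers stand for higher toxicity in this test and higher numbers for lower toxicity in this test), compound 1 gives only a limit, > 100000 nM. In this assay, among the compounds with values here, compound 2 gives 88200 nM, the only number in the set. The other value shown, that of compound 1, is a limit and not a number. Within the data shown here, the step of an at least 1.1-fold lower number from compound 1 to compound 2 (0.05 log units; that floor lies within the scatter) is the single measured step, and it rests on (the limit of > 100000 nM in this assay, at which 1 of the 2 values shown sits), so its true size is open.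

Compound 3 `O=C(/N=C(/NC(=O)c1cc2ccccc2s1)[Se]Cc1ccccc1)c1cc2ccccc2s1` carries the change (a group of 8 heavy atoms (7 carbon, 1 selenium; one six-membered aromatic ring of carbon only) in place of a group of 2 heavy atoms (1 carbon, 1 sulfur; no ring), on a carbon with a double bond to nitrogen). Among the measured compounds shown here, no measured step covers the entry of the larger group; the one measured step, an at least 1.1-fold lower number from compound 1 to compound 2 (0.05 log units; that floor lies within the scatter), touches only the exchange of selenium for sulfur on the same carbon and lies within the scatter. Compound 3 is therefore expected to sit near compound 2 in this assay. The step of a 1.3-fold lower number from compound 2 to compound 3 (0.10 log units; within the scatter) is expected to be no larger than the scatter, in either direction. The expected value for compound 3 in this assay is 70000 nM, within 20000 nM to 200000 nM.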

Compound 3, concentration lethal to 50% of the cells: > 100000 nM
Compound 3 gave a limit, no number; the forecaster's own chance of this, stated with the estimate: 35%; middle value at least 1.4-fold (0.15 log units) away from the limit.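

Replacing methylsulfanyl with the larger selenium group carrying a six-membered aromatic ring of carbon only, on a carbon with a double bond to nitrogen, gives an at least 1.1-fold higher number from compound 2 to compound 3 (0.05 log units; that floor lies within the scatter), so this change brings no higher toxicity that can be read in this assay. In this assay, from the compounds shown here alone, compound 3 gives > 100000 nM, which is a limit and not a number, so the real size of this step stays open and the phenyl added on the selenium-bound chain carbon cannot be judged either, the step linking the two selenium compounds being unreadable. The series now rests mostly on limits, and compound 2 remains the only compound with a number: the limit of > 100000 nM in this assay, at which 2 of the 3 values shown sit.

The change from compound 2 to compound 3 swaps sulfur for selenium and adds the ring at once, and the compounds shown do not separate these two parts. Still open, going by these compounds, is how a benzylsulfanyl group, or an amine, on the same carbon would read in this assay.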